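The source may hold more compounds than are shown below. What is called first, only, known or untested is meant among the compounds shown, and "the series" means these compounds.

Measured in a functional assay on the whole organism with Rattus norvegicus as the target; a higher number here means that more compound is needed for the effect, a lower number that less compound is needed:
- Compound 1 `Cn1c(=N)sc2cc(OC(F)(F)F)ccc21`: 5 mg/kg
- Compound 2 `N=c1sc2cc(OC(F)(F)F)ccc2n1CC(=O)O`: > 10 mg/kg, a limit of the assay and not a number
- Compound 3 `CCCSCCn1c(=N)sc2cc(OC(F)(F)F)ccc21`: 2.4 mg/kg

Of the two actual numbers in this assay, compound 3 holds the lower one at 2.4 mg/kg, and compound 1 is its nearest neighbour.

The next compound to consider is compound 4 `N=c1sc2cc(OC(F)(F)F)ccc2n1CCS`. It differs from compound 3 as follows: hydrogen in place of propyl on a sulfur. This is hydrogen in place of propyl on a sulfur, so 2-(propylsulfanyl)ethyl becomes 2-sulfanylethyl.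

Going by the values given here, no measured step makes exactly this change. The nearest evidence is a 2.1-fold lower number from compound 1 to compound 3 (0.32 log units; beyond the scatter), seen when (propylsulfanyl)methyl takes the place of hydrogen on a saturated chain carbon bound to an aromatic nitrogen. Two further steps involve carboxy at that carbon: an at least 2.0-fold higher number from compound 1 to compound 2 (0.30 log units; that floor lies within the scatter) and an at least 4.1-fold lower number from compound 2 to compound 3 (0.61 log units; beyond the scatter). These show that this chain end can move the result, but neither says what a bare sulfanyl will do.

Compound 4 keeps only part of the chain that separates compound 3 from compound 1, so some of the modest drop may be lost. The expected step is a 1.7-fold higher number from compound 3 to compound 4 (0.22 log units; within the scatter), towards a higher number. For compound 4 the estimated value is 4 mg/kg, with an expected range of 1.5 mg/kg to 10 mg/kg.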

Compound 4, dose for half-maximal effect: 2 mg/kg
For compound 4 the middle estimate is 2.0-fold (0.30 log units) above the measured one; the range from low to high includes it.
By their numbers in this assay, from the lowest: compounds 4 and 3 (each within the scatter of the next); then compound 1. At a limit, above all of these: compound 2.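

In this assay, taking the propyl off the sulfur gives a 1.2-fold lower number from compound 3 to compound 4 (0.08 log units; within the scatter), so the propyl is not needed to reach a number of this size. Sulfanylmethyl in place of hydrogen gives a 2.5-fold lower number from compound 1 to compound 4 (0.40 log units; beyond the scatter), and sulfanylmethyl in place of carboxy gives an at least 5.0-fold lower number from compound 2 to compound 4 (0.69 log units; beyond the scatter), so the modest step away from compound 1 remains when the chain ends in a bare sulfanyl. The step from compound 2 is only a floor, since compound 2 carries a limit of the assay and not a number: the limit of > 10 mg/kg in this assay, at which 1 of the 4 values shown sits.

The compounds shown leave open whether the sulfur itself matters, since a chain ending in a hydroxyl or an amine in place of the sulfanyl would test this directly. Also open, going by these compounds, is whether a plain ethyl chain, with no sulfur at all, would give a number like that of compound 4, and whether a longer chain on the sulfur, such as butyl, would still leave the number unmoved.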